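The compounds below may be only part of what the source reports. "The series", "measured", "known", "first", "only" and "open" are said of these compounds alone.

Measured compounds:
Compound 1 `Nc1c(Br)cc(Br)cc1/C=C(\C(=O)c1ccc(Br)cc1)S(=O)(=O)c1ccc(Br)cc1` gives 25000 nM in a functional assay on DU-145 cells (Homo sapiens) for inhibition, read by trypan blue exclusion, with a stated time of 96 h; a higher number here means a weaker inhibitor of growth, a lower number a stronger inhibitor of growth.
Compound 2 `O=C(/C(=C\c1ccc(Cl)cc1Cl)S(=O)(=O)c1ccc(Br)cc1)c1ccc(Br)cc1` gives 10000 nM in this assay.
Compound 3 `COc1ccccc1/C=C(/Sc1ccc(C)cc1)C(=O)c1ccc(Cl)cc1` gives 25000 nM in this assay.

Compound 2 stands lowest of these three numbers, and so is the strongest inhibitor of growth among them. For the measured compounds named here, its nearest neighbour is compound 1, and the single change between them gives a 2.5-fold lower number from compound 1 to compound 2 (0.40 log units; beyond the scatter). Going by the values given here, compound 3 also gives a higher number than compound 2, but it differs in more than one place, so no single step can be drawn from it.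

Compound 4 `COc1ccc(/C=C(\C(=O)c2ccc(Br)cc2)S(=O)(=O)c2ccc(Br)cc2)cc1` differs from compound 2 in one place: 4-methoxyphenyl in place of 2,4-dichlorophenyl on a double-bonded chain carbon bound to a double-bonded chain carbon. Among the compounds with values here, the only measured step at this place is a 2.5-fold lower number from compound 1 to compound 2 (0.40 log units; beyond the scatter), which shows that swapping the aryl group on the double-bonded chain carbon moves the number only modestly. Within the data shown here, the one measured compound bearing a methoxyphenyl at this place, compound 3, sits higher than compound 2 in this assay, which leans the expectation toward a modestly higher number. In this assay compound 4 is therefore expected to give 20000 nM, within 8000 nM to 50000 nM. This expected step is a 2.0-fold higher number from compound 2 to compound 4 (0.30 log units; within the scatter).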

Compound 4, concentration for 50% growth inhibition: 25000 nM
Estimate against measurement, compound 4: 1.3-fold (0.10 log units) below; the measured number falls inside the stated range.
By their numbers in this assay, from the lowest: compound 2; then compounds 1, 3 and 4 (each within the scatter of the next).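

In this assay the new step, a 2.5-fold higher number from compound 2 to compound 4 (0.40 log units; beyond the scatter), shows that the lower number of compound 2 is lost with 4-methoxyphenyl as well as with 2-amino-3,5-dibromophenyl, so on this double-bonded chain carbon 2,4-dichlorophenyl now stands apart from two different aryl groups rather than one. The second step, no change at the digits printed from compound 1 to compound 4 (within the scatter), shows that these two differently substituted rings cannot be told apart here, even though they carry different groups. Nothing shown explains why the 2,4-dichlorophenyl compound differs from the other two.

Whether both chlorines are needed remains open, as neither 4-chlorophenyl nor 2-chlorophenyl stands at this place among the compounds shown. Also open, as far as these compounds go, is what an unsubstituted phenyl or a cyclohexyl ring would give here.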